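The compounds below may be only part of what the source reports. "The series", "measured", "known", "first", "only" and "open" are said of these compounds alone.

Working notes on the series. Compound 1 `Cc1cccc(N2CCN(C(=O)C(C)N3C(=O)CC(C)C3=O)CC2)c1` has no result in a functional assay on the whole organism (strain Swiss) with Mus musculus as the target, with a stated time of 0.25 h; on this read-out higher numbers stand for an effect only at larger amounts of compound and lower numbers for an effect already at smaller amounts; its entry reads "not determined" (no result reported). Compound 3 `CC(C(=O)N1CCN(c2ccccc2)CC1)N1C(=O)CC(C)(C)C1=O` is in the same position, with "not determined" (no result reported) in this assay. Going by the values given here, compound 2 `CCC(C(=O)N1CCN(c2cccc(Cl)c2)CC1)N1C(=O)CC(C)C1=O` is the only member with a reported entry in this assay, and that entry is a limit of the assay, > 130 mg/kg, not a number. Among the compounds with values here, the only anchor for the series is therefore (the limit of > 130 mg/kg in this assay, at which 1 of the 3 values shown sits), and no step between measured compounds can be drawn from what is in hand.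

Compound 4 `CC1CC(=O)N(C(C)C(=O)N2CCN(c3cccc(C(F)(F)F)c3)CC2)C1=O` differs from compound 1 by trifluoromethyl in place of methyl on an aromatic carbon. Within the data shown here, with no measured step to lean on, the change from compound 1 to compound 4 is expected to move the dose for half-maximal effect by no more than the usual scatter, in no fixed direction. Compound 4 is accordingly expected to give about 150 mg/kg in this assay, within 60 mg/kg to 400 mg/kg. A substantial chance remains that only a limit is reported for compound 4.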

Compound 4, dose for half-maximal effect: 65.7 mg/kg
Estimate against measurement, compound 4: 2.3-fold (0.36 log units) above; the range from low to high includes it.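

No new step can be read from compound 4, since compound 1, which differs from it in one place, carries no single number to set against it. The compounds shown leave open what trifluoromethyl in place of methyl on an aromatic carbon does in this assay.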